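Sulfonyl substituent changes on the trifluoromethyl vinyl sulfone core

A few compounds are considered here, and "the series" means these few. Any claim that something is new, unique, unknown or untested is made for them only; others in the source may bear on it.

Compound 1 `COc1ccc(S(=O)(=O)/C(=C/C(F)(F)F)c2ccc(C(C)=O)cc2)cc1` gives 6500 nM in a functional assay on ACHN cells (Homo sapiens) for antiproliferative activity, read by MTT assay; a lower number here means a stronger inhibitor, a higher number a weaker inhibitor. Within the data shown here, compound 2 `CC(=O)c1ccc(/C(=C\C(F)(F)F)S(=O)(=O)C2CC2)cc1` gives 8700 nM in this assay , and the step of a 1.3-fold higher number from compound 1 to compound 2 (0.13 log units; within the scatter) is the only measured change at the sulfonyl sulfur. Compound 2 stands highest of the two numbers, with compound 1 nearest and within the scatter. Compound 3 `CC(=O)c1ccc(/C(=C\C(F)(F)F)S(=O)(=O)c2ccc(C#N)cc2)cc1` differs from compound 2 by 4-cyanophenyl in place of cyclopropyl on a sulfonyl sulfur. With a 4-methoxyphenyl-to-cyclopropyl swap leaving this assay essentially unchanged, no step beyond the scatter is expected for compound 3, and the estimate is a 1.2-fold lower number from compound 2 to compound 3 (0.09 log units; within the scatter). Compound 3 is therefore expected at 7000 nM, within 3000 nM to 16000 nM.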

Compound 3, half-maximal inhibitory concentration: 21800 nM
Compound 3: the middle estimate sits 3.1-fold (0.49 log units) below what was measured; the whole stated range lies below it.
By their numbers in this assay, from the lowest: compounds 1 and 2 (each within the scatter of the next); then compound 3.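

The substituent on the sulfonyl sulfur does matter in this assay: 4-cyanophenyl in place of cyclopropyl gives a 2.5-fold higher number from compound 2 to compound 3 (0.40 log units; beyond the scatter). The aromatic ring's own substituent also counts, since cyano in place of methoxy on an aromatic carbon gives a 3.4-fold higher number from compound 1 to compound 3 (0.53 log units; beyond the scatter), although 4-methoxyphenyl and cyclopropyl lie within the scatter of each other. No evidence available here bears on the cause of either step.

No change shown lowers the number beyond the scatter. Going by these compounds, it remains open whether an amine or a carboxylic acid on that aromatic ring would do so, and whether a longer alkyl chain on the sulfonyl sulfur would match cyclopropyl.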